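Swapping 2-Fluorophenyl for 4-Iodophenyl on the Ring Nitrogen

This account rests on a few compounds, and the source may have more. Where it says the series, first, only, none or still open, it means among the compounds named here.

In an assay on CHO cells for displacement of a labelled ligand from adenosine receptor A1 (Homo sapiens), read by scintillation counting, with a stated time of 90 min, tested at 1 uM, in the presence of a further agent that is not named here (on this read-out higher numbers stand for more inhibition at the one concentration tested (going by the name of the read-out) and lower numbers for less inhibition), compound 1 `CCCn1c(=O)[nH]c2nc(-c3ccc(S(=O)(=O)N4CCN(c5ccc(F)cc5)CC4)cc3)[nH]c2c1=O` gives 14% and compound 2 `CCCn1c(=O)[nH]c2nc(-c3ccc(S(=O)(=O)N4CCN(c5ccccc5F)CC4)cc3)[nH]c2c1=O` gives 13%. Within the data shown here, compound 2 thus holds the lowest of the two numbers, with compound 1 nearest, and the single measured step, a number 1 percentage points lower from compound 1 to compound 2 (within the scatter), stays within the scatter. Compound 3 `CCCn1c(=O)[nH]c2nc(-c3ccc(S(=O)(=O)N4CCN(c5ccc(I)cc5)CC4)cc3)[nH]c2c1=O` differs from compound 2 by 4-iodophenyl in place of 2-fluorophenyl on an amine nitrogen in a ring. Among the measured compounds shown here, the only step that bears on this change exchanged one fluorophenyl for another and did not move the read-out beyond the scatter, so no step beyond the scatter is expected here, a number 1 percentage points higher from compound 2 to compound 3 (within the scatter). Compound 3 is accordingly estimated at 14%, expected to fall between 2% and 28%.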

Compound 3, a percentage reported as inhibition, at one concentration (the size of the read-out at that concentration, not a potency): 24%
Compound 3: middle estimate off by 10 percentage points, on the low side, and the stated range covers the measured number.
By their numbers in this assay, from the lowest: compounds 2, 1 and 3 (each within the scatter of the next, the first and the last beyond it).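

On the ring nitrogen, the aryl group can move this assay beyond the scatter: 4-iodophenyl in place of 2-fluorophenyl gives a number 11 percentage points higher from compound 2 to compound 3 (beyond the scatter) as a step, which the exchange of one fluorophenyl for another did not. Iodo in place of fluoro on an aromatic carbon gives a number 10 percentage points higher from compound 1 to compound 3 (within the scatter) and so does not clear the scatter. Nothing available explains this difference. The compounds shown leave open how an unsubstituted phenyl, a 4-chlorophenyl or a benzyl on this nitrogen would read, and whether a 2-iodophenyl would match compound 3 .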